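Methyl for Methoxy Across Two Related Cores

This account rests on a few compounds, and the source may have more. Where it says the series, first, only, none or still open, it means among the compounds named here.

Compound 1 `Cc1ccc(CSc2nc3nc(C)cc(Nc4cc(-c5ccccc5)[nH]n4)n3n2)cc1` gives 7310 nM in a functional assay on PC-9 cells (Homo sapiens) for inhibition, read by MTT assay, with a stated time of 72 h; on this read-out higher numbers stand for weaker inhibition and lower numbers for stronger inhibition.
Compound 2 `COc1ccc(CSc2nc3nc(C)cc(Nc4cc(-c5ccccc5)[nH]n4)n3n2)cc1` gives 8110 nM in this assay.
Compound 3 `COc1ccc(Cn2ccc(Nc3cc(C)nc4nc(SCc5ccc(Br)cc5)nn34)n2)cc1` gives > 50000 nM in this assay.

Compounds 1 and 2 share one core and differ only by methyl in place of methoxy on an aromatic carbon. The step of a 1.1-fold lower number from compound 2 to compound 1 (0.05 log units; within the scatter) is within the scatter, so the two values show no ordering between them in this assay.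

Compound 3 carries a different core; how it differs from compound 2 is not broken down here. For compound 3 the result in this assay is a limit of the assay and not a number, as the limit of > 50000 nM in this assay, at which 1 of the 3 values shown sits, shows.

Compound 4 `Cc1ccc(Cn2ccc(Nc3cc(C)nc4nc(SCc5ccc(Br)cc5)nn34)n2)cc1` has not yet been measured in this assay. It differs from compound 3 by methyl in place of methoxy on an aromatic carbon, the same change that separates compound 2 from compound 1, and it sits in the same place. On that measured pair the change moved the number by a 1.1-fold lower number from compound 2 to compound 1 (0.05 log units; within the scatter), which gives no reason to expect a shift beyond the scatter for the new pair either. The expectation therefore rests on compound 3: since its result sits at the limit of > 50000 nM in this assay, at which 1 of the 3 values shown sits, compound 4 is expected to land near the same limit, with the step that the limit leaves unreadable from compound 3 to compound 4 taken as roughly flat. The estimate for compound 4 in this assay is 60000 nM, in a range from 20000 nM to 200000 nM, and the most likely outcome is that the assay again reports only a limit.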

Compound 4, half-maximal inhibitory concentration: > 50000 nM
Compound 4: a limit, no number; the forecaster's own chance of this, stated with the estimate: 75%; the middle value does not contradict the limit.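

In this assay, compound 3 and compound 4 each return only a limit of the assay and not a number, so no step can be read between them: the limit of > 50000 nM in this assay, at which 2 of the 4 values shown sit.

The compounds shown leave open what number either compound would carry, and so whether methyl in place of methoxy shifts the result at all on the core of compound 3.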